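Three Limits and a Shortened Ether Tail

This account rests on a few compounds, and the source may have more. Where it says the series, first, only, none or still open, it means among the compounds named here.

Compound 1 `CC(C)N(Cc1cccc(OCCCCCC(=O)O)c1)C(=O)c1ccccc1` in an ADME assay on Raji cells (Homo sapiens) for cytotoxicity, read by CellTiter-Glo and resazurin assay, with a stated time of 72 h (a higher number here means that more compound is needed for the effect, a lower number that less compound is needed), gives > 26000 nM, a limit of the assay.
Compound 2 `CC(C)N(Cc1cccc(OCCCCCC(=O)O)c1)C(=O)c1ccc(-c2ccsc2)cc1` in this assay gives > 26000 nM, again a limit.
Compound 3 `CC(C)N(Cc1cccc(OCCCCCC(=O)O)c1)C(=O)c1ccc(-c2cccc(OCc3ccccc3)c2)cc1` in this assay gives > 26000 nM, also a limit.

All three measured compounds share one core and differ only at the far end of the benzamide. Compound 3 stands at the same limit as the other two; its value is not a number but the point at which the assay stops reading. Going by the values given here, the one step that can be drawn, a step that the two limits leave unreadable from compound 1 to compound 2, runs between two limits and so gives no readable size. Among the compounds with values here, the single piece of evidence that bears on the series is the limit of > 26000 nM in this assay, at which 3 of the 3 values shown sit.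

Compound 4 `CCOc1cccc(-c2ccc(C(=O)N(Cc3cccc(OCCCCCC(=O)O)c3)C(C)C)cc2)c1` differs from compound 3 in one place: methyl in place of phenyl on a saturated chain carbon bound to an oxygen on an aromatic ring. Within the data shown here, no measured step covers a change of this kind, so the expectation for compound 4 rests only on where compound 3 and its companions sit. Among the measured compounds shown here, since every value so far is a limit, the step from compound 3 to compound 4 is expected to be a step that the limit leaves unreadable from compound 3 to compound 4, with no reading beyond the scatter anticipated. Compound 4 is therefore estimated at 40000 nM, within a range from 20000 nM to 120000 nM, and most probably the assay will again report only its limit.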

Compound 4, half-maximal effective concentration: > 20800 nM
Compound 4: no number, only a limit (the forecaster's own chance of this, stated with the estimate: 85%); the middle value lies beyond the limit too.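

The steps from compound 1, compound 2 and compound 3 to compound 4 all run between two limits in this assay, and none of them can be read. The compounds shown leave open whether any of these groups, from thiophen-3-yl to 3-ethoxyphenyl, changes the half-maximal effective concentration at all: every result here is a limit, not a number.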